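Methyl-to-hydrogen step in the series: estimate for compound 4

The source may hold more compounds than are shown below. What is called first, only, known or untested is meant among the compounds shown, and "the series" means these compounds.

Compound 1 `COc1ccccc1-c1cc(O)c2ccc(C)nc2n1` gives 79400 nM in a functional assay on cells (Tumor Cell line, Homo sapiens) for cytotoxicity; a higher number here means a weaker inhibitor of growth, a lower number a stronger inhibitor of growth. Compound 2 `COc1ccccc1-c1cc(O)c2cccnc2n1` gives 40700 nM in this assay; the step of a 2.0-fold lower number from compound 1 to compound 2 (0.29 log units; within the scatter) is hydrogen in place of methyl on an aromatic carbon. Compound 3 `COc1cccc(-c2cc(O)c3c(C)ccnc3n2)c1` gives 58.9 nM in this assay; the difference between the core of compound 3 and the core of compound 1 is not broken down here. Compound 4 `COc1cccc(-c2cc(O)c3cccnc3n2)c1` is not yet measured; it differs from compound 3 by hydrogen in place of methyl on an aromatic carbon. This is the same kind of change as from compound 1 to compound 2, but at a different place: there the methyl stood next to the ring nitrogen, para to a fused ring; here it stands ortho to a fused ring, opposite the ring nitrogen. Because a 2.0-fold lower number from compound 1 to compound 2 (0.29 log units; within the scatter) stayed within the scatter, the step from compound 3 to compound 4 is expected to be small, a 1.2-fold lower number from compound 3 to compound 4 (0.07 log units; within the scatter). Compound 4 is expected to give about 50 nM in this assay, with a range of 15 nM to 200 nM.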

Compound 4, concentration for 50% growth inhibition: 135 nM
Compound 4: the middle estimate sits 2.7-fold (0.43 log units) below what was measured; the range from low to high includes it.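

In this assay, hydrogen in place of methyl on an aromatic carbon gives a 2.3-fold higher number from compound 3 to compound 4 (0.36 log units; beyond the scatter), a modest step. Set beside the earlier step, this change does not carry over as one fixed step from one core to the other: the same change on two cores in this assay, a 2.0-fold lower number (0.29 log units; within the scatter) from compound 1 to compound 2 and a 2.3-fold higher number (0.36 log units; beyond the scatter) from compound 3 to compound 4, 4.5-fold (0.65 log units) apart, beyond the scatter of two such steps With only one pair on each core, and the two pairs differing both in where the methyl stands and in the rest of the structure, the data do not show which of these differences matters, nor do they give a rule for other cores.

The compounds shown leave open how a larger or different group on that aromatic carbon, such as an amine or a longer chain, would compare with methyl and hydrogen on the core of compound 3.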